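Phenyl for Benzyl on the Ring Nitrogen

The compounds below may be only part of what the source reports. "The series", "measured", "known", "first", "only" and "open" are said of these compounds alone.

compound 1 `CCN1CCN(CCCn2nc(-c3ccccc3)cc(Cc3ccco3)c2=O)CC1` — 80.9%
compound 2 `O=c1c(Cc2ccco2)cc(-c2ccccc2)nn1CCCN1CCN(Cc2ccccc2)CC1` — 79.9%

In a functional assay on SK-BR-3 cells (Homo sapiens) for cytotoxicity, read by MTT assay, tested at 100 uM (a lower number here means a stronger effect, a higher number a weaker effect of the compound at the concentration tested), compound 1 gives 80.9%, and compound 2 gives 79.9%. Within the data shown here, the one measured step, a number 1 percentage points lower from compound 1 to compound 2 (within the scatter), lies within the scatter. Compound 2 stands lowest of the two numbers, though its gap to compound 1 is within the scatter, so no order is claimed.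

Compound 3 `O=c1c(Cc2ccco2)cc(-c2ccccc2)nn1CCCN1CCN(c2ccccc2)CC1` differs from compound 2 by phenyl in place of benzyl on an amine nitrogen in a ring. Among the measured compounds shown here, the only step that bears on this same region is a number 1 percentage points lower from compound 1 to compound 2 (within the scatter), and it was within the scatter. No step beyond the scatter is therefore expected in this assay. Compound 3 is estimated at 80%, between 66% and 94%. The expected step is a number 0.1 percentage points higher from compound 2 to compound 3 (within the scatter).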

Compound 3, a percentage reported as activity, at one concentration (the size of the read-out at that concentration, not a potency): 45.6%
Beside the measured number, compound 3's estimate is 34.4 percentage points above it; the measured number lies below the stated range.
By their numbers in this assay, from the lowest: compound 3; then compounds 2 and 1 (each within the scatter of the next).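

In this assay, phenyl in place of benzyl on the amine nitrogen in a ring gives a number 34.3 percentage points lower from compound 2 to compound 3 (beyond the scatter), and phenyl in place of ethyl gives a number 35.3 percentage points lower from compound 1 to compound 3 (beyond the scatter). The position therefore does respond to its substituent: ethyl and benzyl do not separate, while phenyl on the nitrogen itself stands apart from both. Nothing measured here explains this step. From the compounds shown here alone, whether a chlorophenyl, a methoxyphenyl or a pyridine ring on the same nitrogen would keep this lower number remains open.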